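A few compounds are considered here, and "the series" means these few. Any claim that something is new, unique, unknown or untested is made for them only; others in the source may bear on it.

The measured compounds and their values in a functional assay on MCF7 cells (Homo sapiens) for antiproliferative activity, read by sulforhodamine B assay, with a stated time of 48 h; a higher number here means a weaker inhibitor of growth, a lower number a stronger inhibitor of growth:
compound 1, `COc1ccc(Cn2cc(CNC(=O)c3cn(-c4ccccc4)nc3-c3ccc(F)cc3)nn2)cc1`, gives 650 nM
compound 2, `COc1cc(Cn2cc(CNC(=O)c3cn(-c4ccccc4)nc3-c3ccc(F)cc3)nn2)cc(OC)c1`, gives 2500 nM
compound 3, `COc1cc(Cn2cc(CNC(=O)c3cn(-c4ccccc4)nc3-c3ccc(F)cc3)nn2)cc(OC)c1OC`, gives 4300 nM

Compound 2 stands second highest of the three numbers. Its nearest neighbour is compound 3, reached by a 1.7-fold higher number from compound 2 to compound 3 (0.24 log units; within the scatter), a step within the scatter; its furthest is compound 1, from which compound 2 is reached by a 3.8-fold higher number from compound 1 to compound 2 (0.59 log units; beyond the scatter), a step beyond the scatter. The third measured step is a 6.6-fold higher number from compound 1 to compound 3 (0.82 log units; beyond the scatter). All three steps change the methoxy pattern of the phenyl on the saturated chain carbon bound to an aromatic nitrogen; none touches the other end of the shared core.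

Compound 4, `COc1cc(Cn2cc(CNC(=O)c3cn(-c4ccccc4)nc3-c3ccc(Cl)cc3)nn2)cc(OC)c1`, differs from compound 2 in one place: chloro in place of fluoro on an aromatic carbon. Among the measured compounds shown here, no measured step bears on this change, since the 4-fluorophenyl is the same in compounds 1, 2 and 3. With nothing measured at this position, compound 4 is expected to differ from compound 2 in this assay by no change at the digits printed from compound 2 to compound 4 (within the scatter), which is no step beyond the scatter. Compound 4 is therefore estimated at 2500 nM, with a range from 1100 nM to 5500 nM.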

Compound 4, concentration for 50% growth inhibition: 150 nM
Beside the measured number, compound 4's estimate is 17-fold (1.22 log units) above it; the measured number lies below the stated range.
By their numbers in this assay, from the lowest: compound 4; then compound 1; then compounds 2 and 3 (each within the scatter of the next).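

The fixed end of the shared core proves to be far from silent in this assay: 4-fluorophenyl to 4-chlorophenyl gives a 17-fold lower number from compound 2 to compound 4 (1.22 log units; beyond the scatter) and so counts as a large step. Only one heavy atom is exchanged, with no ring, hydrogen-bond donor, hydrogen-bond acceptor or net charge entering or leaving, yet this step exceeds the largest step among the methoxy patterns, a 6.6-fold higher number from compound 1 to compound 3 (0.82 log units; beyond the scatter) in that series. The position on the aromatic carbon para to a large group, unchanged across compound 1, compound 2 and compound 3, therefore matters at least as much here as the methoxy pattern at the other end of the molecule, and nothing available explains why this exchange has so large an effect.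

The compounds shown leave open whether the same exchange would carry over to the 4-methoxyphenyl of compound 1 or the 3,4,5-trimethoxyphenyl of compound 3, since it is seen only with the 3,5-dimethoxyphenyl of compound 2. They also leave open how bromo, methyl or trifluoromethyl, or plain hydrogen, would read at this same place, so no trend across substituents can yet be drawn from one pair.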